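The compounds below may be only part of what the source reports. "The series", "measured", "known", "first", "only" and "open" are said of these compounds alone.

Measured compounds: compound 1 `Cc1cc(NC(=O)Cn2nnc(-c3ccccc3)n2)n(C2CCOCC2)n1`, which in an assay on HEK293 cells for activation of Kir3.1/Kir3.2 (Homo sapiens), read by thallium flux (on this read-out lower numbers stand for an effect already at smaller amounts and higher numbers for an effect only at larger amounts of compound), gives 435 nM; compound 2 `Cc1cc(NC(=O)Cn2nnc(-c3ccccc3)n2)n(C(C)C)n1`, which gives 556 nM; compound 3 `Cc1cc(NC(=O)Cn2nnc(-c3ccccn3)n2)n(C2CCCCC2)n1`, which gives 14600 nM.

Compound 3 stands highest of the three numbers; compound 2 is nearest and compound 1 furthest, both gaps beyond the scatter. Compound 4 `Cc1cc(NC(=O)Cn2nnc(-c3cccc(C#N)c3)n2)n(C2CCCCC2)n1` differs from compound 3 by 3-cyanophenyl in place of pyridin-2-yl on an aromatic carbon. Within the data shown here, the only single-place step measured, a 1.3-fold higher number from compound 1 to compound 2 (0.11 log units; within the scatter), concerns the group on the aromatic nitrogen and does not touch the place changed here. Among the measured compounds shown here, no measured step covers the aromatic carbon of the five-membered ring; compounds 1 and 2 both carry phenyl there and show the two lower numbers, while compound 3 with pyridin-2-yl shows the highest. On that showing a lower number is expected for compound 4, with a step of a 9.7-fold lower number from compound 3 to compound 4 (0.99 log units; beyond the scatter). Compound 4 is estimated at 1500 nM, within 400 nM to 6000 nM.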

Compound 4, half-maximal effective concentration: 183 nM
For compound 4 the middle estimate is 8.2-fold (0.91 log units) above the measured one; measured number below the stated range.
By their numbers in this assay, from the lowest: compound 4; then compounds 1 and 2 (each within the scatter of the next); then compound 3.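

In this assay, putting 3-cyanophenyl in place of pyridin-2-yl on the aromatic carbon gives an 80-fold lower number from compound 3 to compound 4 (1.90 log units; beyond the scatter), with the rest of the molecule unchanged, so the group at this place can shift the number strongly. The change removes a ring nitrogen and adds a nitrile in a single step, and this step alone cannot separate the two. No evidence is available to explain the size of this step.

The compounds shown leave open how phenyl itself would compare at this place with cyclohexyl on the aromatic nitrogen. They also leave open how an amine or a carboxylic acid would compare with the nitrile.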